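From phenyl to 3-bromophenyl at the assay limit

The compounds below may be only part of what the source reports. "The series", "measured", "known", "first", "only" and "open" are said of these compounds alone.

Within the data shown here, compound 1 `C=C[C@@](C)(/C=C/c1ccc(Nc2ccc(F)cc2)cc1)CCC=C(C)C` and compound 2 `C=C[C@@](C)(/C=C/c1ccc(-c2ccccc2)cc1)CCC=C(C)C` are the two measured members, both tested in a functional assay on NALM-6 cells (Homo sapiens) for cytotoxicity, with a stated time of 72 h; a higher number here means that more compound is needed for the effect, a lower number that less compound is needed. Compound 1 gives > 43400 nM, which is a limit and not a number. Compound 2 gives > 43400 nM, which is also a limit. Among the measured compounds shown here, compound 2 therefore has no readable position, and the series so far shows only (the limit of > 43400 nM in this assay, at which 2 of the 2 values shown sit).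

The next member is compound 3 `C=C[C@@](C)(/C=C/c1ccc(-c2cccc(Br)c2)cc1)CCC=C(C)C`, which has bromo in place of hydrogen on an aromatic carbon, meta to a large group: bromo in place of hydrogen on an aromatic carbon. For the measured compounds named here, the only measured step, a step that the two limits leave unreadable from compound 1 to compound 2, gives no size or direction to carry over. No step beyond the scatter is therefore expected in this assay, and another limit is the likeliest reading, although a measurable value cannot be ruled out. The estimated move is an at least 1.0-fold lower number from compound 2 to compound 3 (0.03 log units; that floor lies within the scatter). Compound 3 is expected at 40000 nM, with an estimated range from 15000 nM to 60000 nM.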

Compound 3, half-maximal effective concentration: > 43400 nM
Compound 3 was reported as a limit (the forecaster's own chance of this, stated with the estimate: 70%); middle value at least 1.0-fold (0.03 log units) from the limit.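

No new step can be read among compound 1, compound 2 and compound 3 in this assay, since all three results are limits and not numbers: the limit of > 43400 nM in this assay, at which 3 of the 3 values shown sit.

The compounds shown leave open whether phenyl, 3-bromophenyl or (4-fluorophenyl)amino on the shared core differ at all in this assay, and whether any member of this series gives a measurable value.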